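Compound 1 and the step to compound 4

The source may hold more compounds than are shown below. What is called first, only, known or untested is meant among the compounds shown, and "the series" means these compounds.

- compound 1 `CCn1c(C(=O)NCCN(C)C)ccc1C(CC)(CC)c1ccc(OCCC(O)(CC)CC)c(C)c1`: 240 nM
- compound 2 `CCn1c(C(=O)NCCN)ccc1C(CC)(CC)c1ccc(OCCC(O)(CC)CC)c(C)c1`: 1590 nM
- compound 3 `C=CCN(C)C(=O)c1ccc(C(CC)(CC)c2ccc(OCCC(O)(CC)CC)c(C)c2)n1CC`: > 50000 nM, a limit of the assay

In a functional assay on HepG2 cells (Homo sapiens) for antiproliferative activity, read by MTT assay, with a stated time of 48 h (on this read-out higher numbers stand for weaker inhibition and lower numbers for stronger inhibition), compound 1 gives 240 nM, the lowest number of the series. Compound 4 `C#CC(C)OC(=O)c1ccc(C(CC)(CC)c2ccc(OCCC(O)(CC)CC)c(C)c2)n1CC` has not yet been measured. It carries (1-methylprop-2-yn-1-yl)oxy in place of (2-(dimethylamino)ethyl)amino on a carbonyl carbon.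

Within the data shown here, two measured steps bear on this change. Altering only the end of the chain gives a 6.6-fold higher number from compound 1 to compound 2 (0.82 log units; beyond the scatter), a modest step. Replacing the whole group on the carbonyl carbon gives an at least 200-fold higher number from compound 1 to compound 3 (2.31 log units; beyond the scatter), a large step. The whole group also leaves in compound 4, so a large step to a higher number is expected in this assay, on the precedent of an at least 200-fold higher number from compound 1 to compound 3 (2.31 log units; beyond the scatter). The assay may well report only a limit for this compound.

For compound 4 the estimated value is 30000 nM, with an expected range from 8000 nM to 50000 nM. The expected change is a 130-fold higher number from compound 1 to compound 4 (2.10 log units; beyond the scatter).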

Compound 4, half-maximal inhibitory concentration: > 50000 nM
Compound 4: a limit, no number; the forecaster's own chance of this, stated with the estimate: 55%; at least 1.6-fold (0.22 log units) between middle value and limit.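

On the carbonyl carbon, a second replacement of (2-(dimethylamino)ethyl)amino, this time by (1-methylprop-2-yn-1-yl)oxy, again ends at a limit of the assay and not at a number: the limit of > 50000 nM in this assay, at which 2 of the 4 values shown sit.

In this assay the entering group holds no nitrogen, unlike the allyl(methyl)amino of compound 3, yet the change still gives an at least 200-fold higher number from compound 1 to compound 4 (2.31 log units; beyond the scatter) and also an at least 31-fold higher number from compound 2 to compound 4 (1.49 log units; beyond the scatter), so a nitrogen attached to the carbonyl carbon does not by itself keep a readable value. The step from compound 3 to compound 4 cannot be read, and these two replacements cannot be ranked.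

From the compounds shown here alone, it remains open how much of the (2-(dimethylamino)ethyl)amino group is needed. A longer chain ending in dimethylamino, or a chain ending in morpholine or in a hydroxyl group, could show this.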